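Dropping One Trifluoromethyl from Compound 3

The source may report more compounds than this note shows. Statements on the series, on what has been measured and on what is new or still open speak of the compounds shown alone.

Of the compounds shown here, three have been measured in a functional assay on T47D cells (Homo sapiens) for inhibition, read by sulforhodamine B assay, with a stated time of 48 h, tested at 100 uM; on this read-out higher numbers stand for a weaker effect at the one concentration tested and lower numbers for a stronger effect. Compound 1 `O=C(Nc1cccc(-n2cc(-c3ccncc3)c(-c3cc(O)cc(Cl)c3)n2)c1)Nc1ccc(Cl)c(C(F)(F)F)c1` gives -52%. Among the measured compounds shown here, compound 2 `O=C(Nc1cccc(-n2cc(-c3ccncc3)c(-c3cc(O)cc(Cl)c3)n2)c1)Nc1ccc(Cl)c(Cl)c1` gives -39%; it differs from compound 1 in one place, and that step, a number 13 percentage points higher from compound 1 to compound 2 (beyond the scatter), is the only measured change that touches the kind of group at issue here. Compound 3 `COc1cc(Cl)cc(-c2nn(-c3cccc(NC(=O)Nc4cc(C(F)(F)F)cc(C(F)(F)F)c4)c3)cc2-c2ccncc2)c1` gives -22%, the highest number of the three, standing beyond the scatter from both compound 1 and compound 2.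

Compound 4 `COc1cc(Cl)cc(-c2nn(-c3cccc(NC(=O)Nc4cccc(C(F)(F)F)c4)c3)cc2-c2ccncc2)c1` has not yet been measured. It differs from compound 3 by a single change: hydrogen in place of trifluoromethyl on an aromatic carbon. The step from compound 1 to compound 2 put chloro in place of trifluoromethyl on an aromatic carbon and moved the read-out to a higher number by a modest amount. For the measured compounds named here, putting hydrogen in place of trifluoromethyl is a different swap, and no measured pair shows exactly this change, so that step is only a rough guide. On that basis a modest shift toward a higher number is expected, though a result within the scatter would not be surprising. Compound 4 is therefore estimated at -10%, within a range from -35% to 15%. The expected step from this estimate is a number 12 percentage points higher from compound 3 to compound 4 (beyond the scatter).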

Compound 4, a percentage reported as activity, at one concentration (the size of the read-out at that concentration, not a potency): -25%
For compound 4 the middle estimate is 15 percentage points above the measured one; measured number inside the range.
By their numbers in this assay, from the lowest: compound 1; then compound 2; then compounds 4 and 3 (each within the scatter of the next).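

In this assay, removing one trifluoromethyl group and leaving hydrogen on that aromatic carbon gives a number 3 percentage points lower from compound 3 to compound 4 (within the scatter), so this group can be lost here with no change that stands clear of the scatter, as long as the remaining trifluoromethyl group stays in place. Among the compounds shown here, the only earlier step that removed a trifluoromethyl group, a number 13 percentage points higher from compound 1 to compound 2 (beyond the scatter), put chloro in its place on a different compound, so the two steps together show no single effect of losing this group. Nothing available explains why the number holds steady in this step.

As far as these compounds go, it remains open whether other groups on this carbon, such as an amine or a carboxylic acid, would shift the read-out, given that only trifluoromethyl and hydrogen appear there so far. From the compounds shown here alone, it is equally open whether removing the remaining trifluoromethyl group as well would leave the number unchanged, and whether the same swap to hydrogen would behave alike on the hydroxy-bearing compounds, compound 1 and compound 2.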